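A few compounds are considered here, and "the series" means these few. Any claim that something is new, unique, unknown or untested is made for them only; others in the source may bear on it.

The study opens with two compounds that reach only the boundary of the assay. Compound 1 `CCC(COc1cccc(C(F)(F)F)c1)OC(=O)NCCCc1ccccc1`, tested in an assay for inhibition of zeta-carotene desaturase, chloroplastic/chromoplastic (Capsicum annuum), using a Dixon plot, with a stated time of 8 h (on this read-out lower numbers stand for stronger inhibition and higher numbers for weaker inhibition), gives > 100000 nM, which is a limit of the assay and not a number. Compound 2 `CCC(COc1cccc(Cl)c1)OC(=O)NC(C)c1ccccc1` in this assay gives > 100000 nM, again a limit rather than a measured value. Both compounds therefore share (the limit of > 100000 nM in this assay, at which 2 of the 2 values shown sit), and nothing measured separates them. The next compound, compound 3 `CCC(COc1cccc(Cl)c1)OC(=O)N[C@@H](C)c1ccccc1`, differs from compound 2 in one respect: the two compounds have the same atoms and bonds; at least one stereo element is drawn with a configuration in one of them and without one in the other: 1 of 2 stereo elements differ; a stereocentre at a saturated chain carbon is drawn without a configuration in compound 2 and S in compound 3. Among the compounds with values here, no step between measured compounds exists here, so the size of the change in this assay can only be anticipated: since compound 2 rests at a limit > 100000 nM, compound 3 is expected to stay at or near that boundary, with no step beyond the scatter. Compound 3 is accordingly estimated at 150000 nM in this assay, within a range from 50000 nM to 500000 nM, corresponding to an expected step that the limit leaves unreadable from compound 2 to compound 3.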

Compound 3, half-maximal inhibitory concentration: > 100000 nM
Compound 3: only a limit was reported; the forecaster's own chance of this, stated with the estimate: 85%; the middle value is on the limit's open side.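

In this assay compound 3 gives > 100000 nM, a limit and not a number. Within the data shown here, compound 2 also rests at a limit, so no step between compound 2 and compound 3 can be read. The compounds shown leave open whether the S configuration at the saturated chain carbon affects inhibition at all.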